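A few compounds are considered here, and "the series" means these few. Any claim that something is new, unique, unknown or untested is made for them only; others in the source may bear on it.

Two compounds share a core in which a protected piperidine is linked through an oxygen to a saturated six-membered ring, which in turn carries an aryl ether. Compound 1 `CC(C)(C)OC(=O)N1CCC(O[C@H]2CC[C@H](Oc3ccc(S(C)(=O)=O)cc3F)CC2)CC1` has a fluorinated methylsulfonylphenyl ether; in a functional assay on isolated protein for agonist activity at Glucose-dependent insulinotropic receptor (Homo sapiens), read by HTRF and cAMP accumulation (on this read-out higher numbers stand for larger maximal responses and lower numbers for smaller maximal responses), compound 1 reaches 113%. Compound 2 `CC(C)(C)OC(=O)N1CCC(O[C@H]2CC[C@H](Oc3ccc(C#N)cc3)CC2)CC1` carries a cyanophenyl ether instead, and in this assay compound 2 reaches 116%, the higher of the two numbers, yet the gap to compound 1 lies within the scatter. Compound 3 `CC(C)(C)OC(=O)N1CCC(O[C@H]2CC[C@H](Oc3ccc(S(C)(=O)=O)nn3)CC2)CC1` differs from compound 2 by 6-(methylsulfonyl)pyridazin-3-yl in place of 4-cyanophenyl on an oxygen on a saturated carbon. With both measured compounds giving full responses, no step beyond the scatter is expected, and from compound 2 to compound 3 the estimated change is a number 6 percentage points lower from compound 2 to compound 3 (within the scatter). Compound 3 is therefore expected to reach about 110%, likely between 90% and 125%.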

Compound 3, largest response reached (Emax), in percent of the reference or control that the assay uses: 97%
Compound 3: the middle estimate sits 13 percentage points above what was measured, within the range that was stated.
By their numbers in this assay, from the lowest: compound 3; then compounds 1 and 2 (each within the scatter of the next).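

In this assay, the group on an oxygen on a saturated carbon can change the maximal response: 6-(methylsulfonyl)pyridazin-3-yl in place of 4-cyanophenyl gives a number 19 percentage points lower from compound 2 to compound 3 (beyond the scatter) for this pair. Among these compounds, this is the first step beyond the scatter, and compound 3 still reaches 97% in this read-out. Nothing shown explains the drop. From the compounds shown here alone, the ring and its substituent change together here, so their separate contributions remain open. Going by these compounds, whether an amine or a carboxylic acid in place of the methylsulfonyl would keep or lower the response also remains open.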